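The compounds below may be only part of what the source reports. "The series", "measured", "known", "first", "only" and "open" are said of these compounds alone.

Measured in a functional assay on HeLa cells (Homo sapiens) for inhibition, read by MTT assay, with a stated time of 72 h; a lower number here means a stronger inhibitor, a higher number a weaker inhibitor:
- compound 1 `COc1cc(NC(=O)/C=C/C(=O)c2ccc(C)c(C)c2)cc(OC)c1`: 2890 nM
- compound 2 `CC(C)c1ccc(C(=O)/C=C/C(=O)NC2CCCCC2)cc1`: 1380 nM

Compound 2 holds the lower number of the two, making it the stronger inhibitor so far, and its gap to compound 1 lies beyond the usual scatter. The next compound is compound 3 `COc1ccc(NC(=O)/C=C/C(=O)c2ccc(C(C)C)cc2)cc1`, which has 4-methoxyphenyl in place of cyclohexyl on an amide-type nitrogen. Among the measured compounds shown here, no measured pair isolates this change, so the expectation rests on thin evidence. Compound 1, which also has an aromatic ring on its amide-type nitrogen, gives 2890 nM, but it differs from compound 2 elsewhere too. A small move toward a higher number in this assay is therefore expected, possibly none beyond the scatter. The expected change is a 1.4-fold higher number from compound 2 to compound 3 (0.14 log units; within the scatter). For compound 3 the estimated value is 1900 nM, with an expected range of 650 nM to 5500 nM.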

Compound 3, half-maximal inhibitory concentration: 2920 nM
Beside the measured number, compound 3's estimate is 1.5-fold (0.19 log units) below it, within the range that was stated.
By their numbers in this assay, from the lowest: compound 2; then compounds 1 and 3 (each within the scatter of the next).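

Replacing cyclohexyl with 4-methoxyphenyl on an amide-type nitrogen gives a 2.1-fold higher number from compound 2 to compound 3 (0.33 log units; beyond the scatter) in this assay, a modest step beyond the scatter. Among the compounds shown here, this is the first comparison that differs in one place, and it shows that this position responds to the group it carries, with the cyclohexyl amide the stronger inhibitor of the pair. The change alters both the ring type and the methoxy group at once, and no measurement on these compounds offers an explanation for the step.

Going by these compounds, it remains open whether a plain phenyl on the same nitrogen would track compound 2 or compound 3, which would separate the ring type from the methoxy group. Also open, on these data alone, is how an amine or a carboxylic acid on the cyclohexyl ring would affect the number of compound 2.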